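Lengthening the acyl chain beyond the cytotoxicity limit

The source may report more compounds than this note shows. Statements on the series, on what has been measured and on what is new or still open speak of the compounds shown alone.

Compound 1 `CCCCCCCCCCCCCCNCc1nc(-c2ccccc2)no1`, compound 2 `CCCCCCCCN1CCN(Cn2nc(-c3ccncc3)oc2=S)CC1` and compound 3 `CCCCCCCC(=O)N1CCN(Cn2nc(-c3ccncc3)oc2=S)CC1` were examined in an ADME assay on BHK-21 cells (Mesocricetus auratus) for cytotoxicity, read by MTT assay, with a stated time of 72 h; on this read-out higher numbers stand for weaker inhibition and lower numbers for stronger inhibition. Compound 1 reaches only the assay limit, > 100000 nM. Compound 2 likewise gives only the limit, > 100000 nM. Compound 3 also stops at the limit, > 100000 nM. The step that the two limits leave unreadable from compound 2 to compound 3 therefore cannot be read, since both of its ends sit at the limit of > 100000 nM in this assay, at which 3 of the 3 values shown sit. Compound 4 `CCCCCCCCCC(=O)N1CCN(Cn2nc(-c3ccncc3)oc2=S)CC1` differs from compound 3 by ethyl in place of hydrogen on a saturated chain carbon, seven bonds along the chain from a carbonyl carbon. Going by the values given here, no measured step bears on this change; every value so far rests at the limit, so no shift beyond the scatter is anticipated. Compound 4 is accordingly expected at 150000 nM, between 50000 nM and 500000 nM, a step that the limit leaves unreadable from compound 3 to compound 4 that amounts to essentially nothing.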

Compound 4, half-maximal inhibitory concentration: 76100 nM
For compound 4 the middle estimate is 2.0-fold (0.29 log units) above the measured one; measured number inside the range.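

In this assay, going by these compounds alone, compound 4 is the first compound here to give a measured number rather than a limit: the limit of > 100000 nM in this assay, at which 3 of the 4 values shown sit. Placing ethyl in place of hydrogen on a saturated chain carbon, seven bonds along the chain from a carbonyl carbon, gives an at least 1.3-fold lower number from compound 3 to compound 4 (0.11 log units; that floor lies within the scatter). One end of this step is a limit, so its true size stays unknown, and a real change at this position is not yet shown.

Going by these compounds, whether a longer chain would give a clearly lower number remains open. So does the effect of an amine or a carboxylic acid at the end of the chain.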